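Iodo to Furan-3-yl Exchange on Two Related Cores

The source may hold more compounds than are shown below. What is called first, only, known or untested is meant among the compounds shown, and "the series" means these compounds.

Measured compounds:
Compound 1, `Cc1ncnc2c1c(I)cn2[C@@H]1O[C@H](CO)[C@@H](O)[C@H]1O`: 7570 nM
Compound 2, `Cc1ncnc2c1c(-c1ccoc1)cn2[C@@H]1O[C@H](CO)[C@@H](O)[C@H]1O`: > 20000 nM
Compound 3, `Cc1nc(N)c2c(I)cn([C@@H]3O[C@H](CO)[C@@H](O)[C@H]3O)c2n1`: > 20000 nM

In a functional assay on HCT-116 cells (Homo sapiens), read by MTT assay, with a stated time of 72 h (on this read-out lower numbers stand for stronger inhibition and higher numbers for weaker inhibition), compound 1 gives 7570 nM. Compound 2 reaches only the limit of this assay, > 20000 nM. Compound 3 likewise reaches only the limit of this assay, > 20000 nM. The difference between the core of compound 1 and the core of compound 3 is not broken down here.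

The move from compound 1 to compound 2 is furan-3-yl in place of iodo on an aromatic carbon. It produced an at least 2.6-fold higher number from compound 1 to compound 2 (0.42 log units; beyond the scatter), a step whose full size stays hidden because of the limit of > 20000 nM in this assay, at which 2 of the 3 values shown sit.

Compound 4, `Cc1nc(N)c2c(-c3ccoc3)cn([C@@H]3O[C@H](CO)[C@@H](O)[C@H]3O)c2n1`, has not yet been measured in this assay. Within the data shown here, it arises from compound 3 by furan-3-yl in place of iodo on an aromatic carbon, the same kind of change as the one from compound 1 to compound 2, made on the other core.

Because compound 3 already sits at the limit, > 20000 nM, and because the same exchange on the core of compound 1 gave an at least 2.6-fold higher number from compound 1 to compound 2 (0.42 log units; beyond the scatter), compound 4 is expected to stay at or beyond the limit as well. The estimated step is a step that the limit leaves unreadable from compound 3 to compound 4. Compound 4 is thus estimated at 40000 nM, with an expected range from 20000 nM to 100000 nM, and most likely this assay will report only a limit for compound 4 rather than a number.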

Compound 4, half-maximal inhibitory concentration: > 20000 nM
Compound 4: a limit, no number; the forecaster's own chance of this, stated with the estimate: 90%; the middle value lies beyond the limit too.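

In this assay compound 4 gives > 20000 nM, a limit of the assay and not a number. No step from compound 3 to compound 4 can be read, because both compounds stand at that limit: the limit of > 20000 nM in this assay, at which 3 of the 4 values shown sit. The compounds shown leave open how large the exchange of iodo for furan-3-yl is on the core of compound 3, and how far that core differs from the core of compound 1.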